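Ether side-chain variation against cytotoxicity

This account rests on a few compounds, and the source may have more. Where it says the series, first, only, none or still open, it means among the compounds named here.

Three ethers on one shared core have been measured in a functional assay on RKO cells (Homo sapiens) for cytotoxicity, read by MTT assay, with a stated time of 48 h; on this read-out lower numbers stand for stronger inhibition and higher numbers for weaker inhibition. Compound 1 `CC(C)COc1ccc2c(Cl)ccnc2c1` gives 2680 nM, compound 2 `CCCCOc1ccc2c(Cl)ccnc2c1` gives 3050 nM, and compound 3 `Clc1ccnc2cc(OCc3ccccc3)ccc12` gives 2410 nM. Compound 3 carries the lowest of the three numbers, yet every gap is small: a 1.1-fold lower number from compound 1 to compound 3 (0.05 log units; within the scatter), a 1.3-fold lower number from compound 2 to compound 3 (0.10 log units; within the scatter), and likewise a 1.1-fold higher number from compound 1 to compound 2 (0.06 log units; within the scatter). Compound 4 `CCOc1ccc2c(Cl)ccnc2c1` has not been measured in this assay; it differs from compound 3 by methyl in place of phenyl on a saturated chain carbon bound to an oxygen on an aromatic ring. For the measured compounds named here, the steps that bear on this exchange are the two swaps of an alkyl group against phenyl, both within the scatter, so nothing beyond the scatter is expected in this assay. Because a 1.1-fold lower number from compound 1 to compound 3 (0.05 log units; within the scatter) and a 1.3-fold lower number from compound 2 to compound 3 (0.10 log units; within the scatter) are both flat, the expected step is a 1.2-fold higher number from compound 3 to compound 4 (0.07 log units; within the scatter). Compound 4 is estimated at 2800 nM, within a range from 1400 nM to 5600 nM.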

Compound 4, half-maximal inhibitory concentration: 3870 nM
For compound 4 the middle estimate is 1.4-fold (0.14 log units) below the measured one; the range from low to high includes it.
By their numbers in this assay, from the lowest: compounds 3, 1, 2 and 4 (each within the scatter of the next).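

In this assay, methyl in place of phenyl on a saturated chain carbon bound to an oxygen on an aromatic ring removes the whole six-membered aromatic ring, yet gives only a 1.6-fold higher number from compound 3 to compound 4 (0.21 log units; within the scatter). The other two comparisons stay flat as well, with a 1.3-fold higher number from compound 2 to compound 4 (0.10 log units; within the scatter) and a 1.4-fold higher number from compound 1 to compound 4 (0.16 log units; within the scatter), so all four compounds shown remain within the scatter across these steps. No measurement available here accounts for this flatness. Going by these compounds, whether an amine, a carboxylic acid or a longer chain at this place would move the number beyond the scatter remains open.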